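The compounds below may be only part of what the source reports. "The series", "measured", "known", "first", "only" and "open" are said of these compounds alone.

Series notes. The shared core, seen in compound 1 `N[C@H]1CC[C@H](Nc2c(C(=O)NCc3ccc(Cl)cc3)nc(Br)c3cccnc23)CC1`, carries an amide on one side and an amine-bearing substituent on the other. In a functional assay on MDA-MB-435 cells (Homo sapiens) for cytotoxicity, read by MTT assay, with a stated time of 72 h (on this read-out higher numbers stand for weaker inhibition and lower numbers for stronger inhibition), compound 1 gives 1000 nM. Compound 3 `N[C@H]1CC[C@H](Nc2c(C(=O)NC3CCCCC3)nc(Br)c3cccnc23)CC1`, with cyclohexyl in place of 4-chlorobenzyl on the amide-type nitrogen, gives only a limit in this assay, > 10000 nM, and that limit is where one of the three values sits (the limit of > 10000 nM in this assay, at which 1 of the 3 values shown sits). Going by the values given here, the step of an at least 10-fold higher number from compound 1 to compound 3 (1.00 log units; beyond the scatter) is the only measured step between compounds differing in one place, and it concerns the amide side, not the amine chain.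

Compound 2 `NCCNc1c(C(=O)NCc2ccc(F)cc2)nc(Br)c2cccnc12` gives 12000 nM in this assay, the higher of the two numbers obtained; compound 1 gives the lower number.

Compound 4 `NCCCNc1c(C(=O)NCc2ccc(F)cc2)nc(Br)c2cccnc12` differs from compound 2 by aminomethyl in place of amino on a saturated chain carbon, two bonds along the chain from a nitrogen on an aromatic ring. Among the compounds with values here, no measured step touches this chain, so there is no basis for expecting a step beyond the scatter. The value of compound 4 in this assay is therefore estimated at 11000 nM, between 4000 nM and 30000 nM. That estimate implies a step of a 1.1-fold lower number from compound 2 to compound 4 (0.04 log units; within the scatter), expected to stay within the scatter.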

Compound 4, half-maximal inhibitory concentration: 5000 nM
For compound 4 the middle estimate is 2.2-fold (0.34 log units) above the measured one; the range from low to high includes it.
By their numbers in this assay, from the lowest: compound 1; then compound 4; then compound 2.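

In this assay, going by these compounds alone, the step of a 2.4-fold lower number from compound 2 to compound 4 (0.38 log units; beyond the scatter) is the first measured change on the amine chain rather than the amide side, and it shows that going from (2-aminoethyl)amino to (3-aminopropyl)amino moves the read-out modestly but beyond the scatter. With the amide side unchanged in this pair, the lower number goes with the chain carrying the added carbon, though this single pair supports no trend with chain length. Nothing measured here gives a cause for this step.

Going by these compounds, whether a longer aminoalkyl chain, or a dimethylamino or hydroxyl group at the chain end, would carry the change further remains open. Compound 1 differs from compound 2 and compound 4 in more than one place, so the contribution of its amine-bearing substituent cannot be read from these values.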